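The source may report more compounds than this note shows. Statements on the series, on what has been measured and on what is new or still open speak of the compounds shown alone.

Measured compounds:
- compound 1, `Fc1ccc(C2CC(c3ccc(Cl)s3)=NN2c2nc(-c3ccccc3)cs2)cc1`: in a functional assay on A549 cells (Homo sapiens) for antiproliferative activity, read by XTT assay, with a stated time of 24 h (a higher number here means a weaker inhibitor, a lower number a stronger inhibitor), compound 1 reaches only a limit, > 500 ug/mL.
- compound 2, `Cc1ccc(C2=NN(c3nc(-c4ccc(F)cc4)cs3)C(c3ccc(F)cc3)C2)s1`: compound 2 gives 125 ug/mL.
- compound 3, `COc1ccc(-c2csc(N3N=C(c4ccc(C)s4)CC3c3ccc(F)cc3)n2)cc1`: compound 3 gives 184 ug/mL.

Compound 1 stands at the limit of > 500 ug/mL in this assay, at which 1 of the 3 values shown sits; with no number behind it, its place against compound 2 and compound 3 is not fixed. Compound 4, `O=[N+]([O-])c1ccc(-c2csc(N3N=C(c4ccc(Cl)s4)CC3c3ccc(F)cc3)n2)cc1`, differs from compound 1 by nitro in place of hydrogen on an aromatic carbon. Going by the values given here, the only measured step, a 1.5-fold higher number from compound 2 to compound 3 (0.17 log units; within the scatter), concerns a different change on the shared core and says nothing direct about nitro in place of hydrogen. Starting from a limit, the expected step of an at least 1.6-fold lower number from compound 1 to compound 4 (0.22 log units; that floor lies within the scatter) is loosely held; compound 4 is estimated at 300 ug/mL, between 100 ug/mL and 600 ug/mL, with a real chance that again only a limit is reported.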

Compound 4, half-maximal inhibitory concentration: > 500 ug/mL
Compound 4 was reported as a limit (the forecaster's own chance of this, stated with the estimate: 45%); at least 1.6-fold (0.22 log units) between middle value and limit.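

No step can be read from compound 1 to compound 4, because both are reported only as limits: the limit of > 500 ug/mL in this assay, at which 2 of the 4 values shown sit.
As far as these compounds go, whether nitro in place of hydrogen on an aromatic carbon shifts the number in this assay at all stays open.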